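A few compounds are considered here, and "the series" means these few. Any claim that something is new, unique, unknown or untested is made for them only; others in the source may bear on it.

Compound 1 `CCC(CC)O[C@@H]1C=C(C(=O)O)C[C@H](NCc2ccc(Cc3ccccc3)cc2)[C@H]1NC(C)=O` has been tested in an ADME assay on cells (Fibroblast, Gallus gallus) for cytotoxicity, read by CCK-8 assay, with a stated time of 48 h (a lower number here means that less compound is tolerated, a higher number that more compound is tolerated), and no exact figure is available for it. In this assay compound 1 gives > 200000 nM, which is a limit of the assay and not a number. Its two measured relatives stand in the same position. Compound 2 `CCC(CC)O[C@@H]1C=C(C(=O)O)C[C@H](NCc2cccc(OC)c2)[C@H]1NC(C)=O` gives > 200000 nM, also a limit. Compound 3 `CCC(CC)Oc1cccc(CN[C@H]2CC(C(=O)O)=C[C@@H](OC(CC)CC)[C@@H]2NC(C)=O)c1` gives > 200000 nM, again a limit. The whole record so far is therefore (the limit of > 200000 nM in this assay, at which 3 of the 3 values shown sit).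

The next compound, compound 4 `CCC(CC)O[C@@H]1C=C(C(=O)O)C[C@H](NCc2ccc(SCC(C)C)cc2)[C@H]1NC(C)=O`, differs from compound 1 in one place: isobutylsulfanyl in place of benzyl on an aromatic carbon. In words, this is isobutylsulfanyl in place of benzyl on an aromatic carbon of a six-membered aromatic ring of carbon only, para to a large group.

Within the data shown here, only one measured step offers a comparison, as it also changes a group on an aromatic ring. It is a step that the two limits leave unreadable from compound 2 to compound 3, with pentan-3-yl in place of methyl on an oxygen on an aromatic ring. That step has no readable size, so it gives no amount to carry over to the new change. No step beyond the scatter is expected in this assay because of the limit of > 200000 nM in this assay, at which 3 of the 3 values shown sit. The most likely result is therefore another limit. For compound 4 the expected value is 200000 nM, with an estimated range from 100000 nM to 400000 nM. The estimate amounts to an expected a number no higher from compound 1 to compound 4 (the limit leaves the size open).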

Compound 4, half-maximal cytotoxic concentration: > 200000 nM
Compound 4: only a limit was reported (the forecaster's own chance of this, stated with the estimate: 85%); the middle value lies on the limit itself.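

In this assay compound 4 gives > 200000 nM, which is a limit of the assay and not a number. Among these compounds, compound 1 also sits at a limit, so no step from compound 1 to compound 4 can be read, and the record stands as: the limit of > 200000 nM in this assay, at which 4 of the 4 values shown sit. The compounds shown leave open at what concentration any of them would become toxic to these cells.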